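A few compounds are considered here, and "the series" means these few. Any claim that something is new, unique, unknown or untested is made for them only; others in the source may bear on it.

Three members of the series carry the same acrylamide-bearing core and differ only in the group attached at one aromatic carbon of that core. Compound 1 `C=C(Br)C(=O)Nc1cccc(-c2cn3nc(Cc4cccc(OC)c4)sc3n2)c1` gives 1100 nM in a functional assay on FM3A cells (Mus musculus) for inhibition, read by cell counting, with a stated time of 2 days; on this read-out higher numbers stand for weaker inhibition and lower numbers for stronger inhibition. Compound 2 `C=C(Br)C(=O)Nc1cccc(-c2cn3nc(-c4ccc(Cl)cc4)sc3n2)c1` gives 2000 nM in this assay, and compound 3 `C=C(Br)C(=O)Nc1cccc(-c2cn3nc(-c4ccccc4)sc3n2)c1` gives 900 nM in this assay. Compound 3 has the lowest number of the three; against compound 1 the gap is within the scatter, and only the change a 2.2-fold lower number from compound 2 to compound 3 (0.35 log units; beyond the scatter) reaches beyond it.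

Compound 4 `C=C(Br)C(=O)Nc1cccc(-c2cn3nc(-c4ccc(CC)cc4)sc3n2)c1` has not yet been measured. It differs from compound 3 by ethyl in place of hydrogen on an aromatic carbon, the entering group sitting on the six-membered aromatic ring of carbon only, para to a large group. For the measured compounds named here, the one measured step that bears on this is a 2.2-fold lower number from compound 2 to compound 3 (0.35 log units; beyond the scatter), where a group at that same place was removed and the number fell modestly; the step of a 1.8-fold higher number from compound 1 to compound 2 (0.26 log units; within the scatter) changes more than one thing at once and helps less. On that basis the number for compound 4 is expected to move in the opposite direction, by a step of about a 1.7-fold higher number from compound 3 to compound 4 (0.22 log units; within the scatter). Compound 4 is therefore estimated at 1500 nM, with a range of 600 nM to 3800 nM.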

Compound 4, half-maximal inhibitory concentration: 3300 nM
Estimate against measurement, compound 4: 2.2-fold (0.34 log units) below; low and high end bracket the measured number.
By their numbers in this assay, from the lowest: compounds 3, 1, 2 and 4 (each within the scatter of the next, the first and the last beyond it).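

In this assay, ethyl on the six-membered aromatic ring of carbon only, para to a large group, gives a clear rise over hydrogen (a 3.7-fold higher number from compound 3 to compound 4 (0.56 log units; beyond the scatter)), so this place now has two groups, chloro (a 2.2-fold lower number from compound 2 to compound 3 (0.35 log units; beyond the scatter)) and ethyl, whose compounds sit on the opposite side of the scatter from the unsubstituted phenyl of compound 3. The two groups themselves cannot be told apart here (a 1.7-fold higher number from compound 2 to compound 4 (0.22 log units; within the scatter)), so these compounds separate hydrogen from a substituent at this place but do not separate chloro from ethyl. For the compounds shown here, the 4-ethylphenyl group also gives the first step beyond the scatter against the 3-methoxybenzyl group (a 3.0-fold higher number from compound 1 to compound 4 (0.48 log units; beyond the scatter)), whereas the 4-chlorophenyl and phenyl groups both stay within the scatter of compound 1.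

No measurement at hand bears on why the number rises with ethyl at this place. Open too, from the compounds shown here alone, is how a fluoro, a methoxy, an amine, a carboxylic acid or a longer chain such as butyl at the same place would compare with hydrogen, chloro and ethyl.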